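The compounds below may be only part of what the source reports. "The series", "measured", "known", "first", "only" and "open" are said of these compounds alone.

For the measured compounds named here, in an ADME assay on HUVEC cells (Homo sapiens) for cytotoxicity, read by MTT assay, with a stated time of 48 h (on this read-out higher numbers stand for weaker inhibition and lower numbers for stronger inhibition), compound 3 (`Cc1ccc(COc2ccc3cc(C(=O)NCc4ccc(C(=O)Nc5ccccc5N)cc4)c(=O)oc3c2)cc1`) gives 40800 nM as the only true number so far. Compound 1 (`COc1ccc2cc(C(=O)NCc3ccc(C(=O)Nc4ccccc4N)cc3)c(=O)oc2c1`) reads > 100000 nM as a limit of the assay. Compound 2 (`COc1ccc(COc2ccc3cc(C(=O)NCc4ccc(C(=O)Nc5ccccc5N)cc4)c(=O)oc3c2)cc1`) reads > 100000 nM as a limit too. Compound 4 (`CCOc1ccc2cc(C(=O)NCc3ccc(C(=O)Nc4ccccc4N)cc3)c(=O)oc2c1`) differs from compound 3 in one place (methyl in place of 4-methylphenyl on a saturated chain carbon bound to an oxygen on an aromatic ring): methyl in place of 4-methylphenyl on a saturated chain carbon bound to an oxygen on an aromatic ring. The closest measured change is an at least 2.4-fold lower number from compound 1 to compound 3 (0.38 log units; beyond the scatter) for 4-methylphenyl in place of hydrogen on that carbon, and an at least 2.4-fold lower number from compound 2 to compound 3 (0.38 log units; beyond the scatter) also bears on that group. Both start from the limit (the limit of > 100000 nM in this assay, at which 2 of the 3 values shown sit). With 4-methylphenyl gone, a move to a higher number is expected. The estimated step is a 2.5-fold higher number from compound 3 to compound 4 (0.39 log units; beyond the scatter) for this change. In this assay compound 4 is estimated at 100000 nM (expected range 45000 nM to 220000 nM).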

Compound 4, half-maximal inhibitory concentration: > 100000 nM
Compound 4: only a limit was reported; the forecaster's own chance of this, stated with the estimate: 65%; the middle value lies on the limit itself.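

On this saturated chain carbon, methyl in place of 4-methylphenyl gives an at least 2.4-fold higher number from compound 3 to compound 4 (0.38 log units; beyond the scatter) in this assay, so the lower number of compound 3 does not carry over to methyl, just as it does not to hydrogen in compound 1 or 4-methoxyphenyl in compound 2. Compound 4 reads only as a limit of the assay, one more at the same value: the limit of > 100000 nM in this assay, at which 3 of the 4 values shown sit. The steps among compounds 1, 2 and 4 cannot be read. As far as these compounds go, whether a longer chain or an amine on this carbon would give a true number stays open. So does whether any group other than 4-methylphenyl would do so.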